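The compounds below may be only part of what the source reports. "The series", "measured", "known", "first", "only" and "open" are said of these compounds alone.

In a functional assay on HeLa cells (Homo sapiens) for inhibition, read by sulforhodamine B assay (a higher number here means a weaker inhibitor, a lower number a stronger inhibitor), compound 1 `CCCc1ccc(NC2=CC(=O)c3c(nc4n3[C@H]3OC[C@@H](O)[C@H]3OC4)C2=O)cc1` gives 6030 nM as a measured number. For compound 2 `O=C1C(NC2CCCCC2)=CC(=O)c2c1nc1n2[C@H]2OC[C@@H](O)[C@H]2OC1` the assay reports only a limit, > 16000 nM and no number. Compound 3 `O=C1C(Nc2cccc(Cl)c2)=CC(=O)c2c1nc1n2[C@H]2OC[C@@H](O)[C@H]2OC1` has 3-chlorophenyl in place of cyclohexyl on an amine nitrogen and so carries an aromatic ring there, as compound 1 does. Read in reverse, the one measured step of an at least 2.6-fold higher number from compound 1 to compound 2 (0.42 log units; beyond the scatter) for cyclohexyl in place of 4-propylphenyl points toward a lower number of similar size. The expected change is an at least 2.2-fold lower number from compound 2 to compound 3 (0.35 log units; beyond the scatter) as an estimate. Compound 3 is estimated at 7000 nM with an expected range from 2500 nM to 16000 nM in this assay.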

Compound 3, half-maximal inhibitory concentration: 7970 nM
Beside the measured number, compound 3's estimate is 1.1-fold (0.06 log units) below it; low and high end bracket the measured number.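

In this assay two different aromatic rings on the amine nitrogen cannot be told apart, with a 1.3-fold higher number from compound 1 to compound 3 (0.12 log units; within the scatter) and so no order between 3-chlorophenyl and 4-propylphenyl. Going from cyclohexyl to 3-chlorophenyl gives an at least 2.0-fold lower number from compound 2 to compound 3 (0.30 log units; that floor lies within the scatter) as the only reading of that change. This step is a floor and not a size, and compound 2 has only a limit: the limit of > 16000 nM in this assay, at which 1 of the 3 values shown sits.

From the compounds shown here alone, what remains open is how far cyclohexyl truly lies from the aromatic groups. Also open, going by these compounds, is how an unsubstituted phenyl, a 4-chlorophenyl or an open n-butyl chain would read on this nitrogen.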